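Working notes: aryl swap at the chain end of the shared core

The compounds below may be only part of what the source reports. "The series", "measured", "known", "first", "only" and "open" are said of these compounds alone.

Measured compounds:
compound 1, `COc1ccc(C(=O)/C=C/c2ccc(-c3ccccc3)cc2)c2c1C=CC(C)(C)O2`: > 10000 nM
compound 2, `COc1ccc(C(=O)/C=C/c2ccc(C(F)(F)F)cc2)c2c1C=CC(C)(C)O2`: > 10000 nM
compound 3, `COc1ccc(/C=C/C(=O)c2ccc(OC)c3c2OC(C)(C)C=C3)cn1`: > 10000 nM

For the measured compounds named here, every value so far in a functional assay on HT-29 cells (Homo sapiens) for antiproliferative activity, read by MTT assay, with a stated time of 24 h (a higher number here means a weaker inhibitor, a lower number a stronger inhibitor), is a limit of the assay, not a number. Compound 3 stands at that limit, > 10000 nM. The same holds for the other two measured compounds, as summed up by the limit of > 10000 nM in this assay, at which 3 of the 3 values shown sit. Going by the values given here, the only step that joins two measured compounds differing in one place, a step that the two limits leave unreadable from compound 1 to compound 2, is therefore unreadable in size and direction.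

Compound 4, `COc1ccccc1/C=C/C(=O)c1ccc(OC)c2c1OC(C)(C)C=C2`, differs from compound 3 in one place: 2-methoxyphenyl in place of 6-methoxypyridin-3-yl on a double-bonded chain carbon bound to a double-bonded chain carbon. Among the compounds with values here, no measured step bears on this change, and the one recorded step gives no readable size to lean on. The three measured compounds, each sitting at the limit, give no sign that any change of the aryl group at the chain end has brought activity into the measured range.

Compound 4 is therefore expected to sit at or near the limit again, estimated at 15000 nM with a range from 4000 nM to 60000 nM, and most likely reported as a limit rather than a number. The implied step that the limit leaves unreadable from compound 3 to compound 4 is an estimate only, since compound 3 offers no number to step from.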

Compound 4, half-maximal inhibitory concentration: > 10000 nM
Compound 4 was reported as a limit; the forecaster's own chance of this, stated with the estimate: 70%; the middle value lies beyond the limit too.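

No step can be read between compound 3 and compound 4, since both values in this assay are limits and not numbers, and the whole set stands at one limit: the limit of > 10000 nM in this assay, at which 4 of the 4 values shown sit.

The compounds shown leave open whether any aryl group at the chain end of the shared core gives a measurable value in this assay.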